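Working notes on the amide substituent, compound 2 to compound 3

This account rests on a few compounds, and the source may have more. Where it says the series, first, only, none or still open, it means among the compounds named here.

The series is followed in an assay on HEK293 cells for positive allosteric modulation of metabotropic glutamate receptor 5 (Homo sapiens), read by FLIPR, with a stated time of 1 h; a higher number here means that more compound is needed for the effect, a lower number that less compound is needed. Compound 1 `Fc1cccc(C#Cc2nc3c(s2)CN(C2CCC2)CC3)c1` gives > 10000 nM, which is a limit of the assay rather than a number, and the limit of > 10000 nM in this assay, at which 1 of the 2 values shown sits, marks where that limit sits. Compound 2 `CC1CC1C(=O)N1CCc2nc(C#Cc3ccccc3)sc2C1` gives 9.4 nM in this assay, the only number shown so far, so it cannot be placed against any other measured compound as a step. Compound 3 `O=C(C1CCCCO1)N1CCc2nc(C#Cc3ccccc3)sc2C1` has not yet been measured in this assay. It differs from compound 2 by oxan-2-yl in place of 2-methylcyclopropyl on a carbonyl carbon. The rest of the structure is unchanged. Among the measured compounds shown here, no step between measured compounds is available to set the size of such a change, so the expectation rests on compound 2 alone. An oxan-2-yl in place of 2-methylcyclopropyl on the carbonyl carbon is expected to cost a little, a step of a 2.7-fold higher number from compound 2 to compound 3 (0.42 log units; beyond the scatter) in this assay, which may prove no larger than the scatter. Compound 3 is therefore estimated at 25 nM in this assay, with a range from 6 nM to 120 nM.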

Compound 3, half-maximal effective concentration: 320 nM
The estimate for compound 3 lay 13-fold (1.11 log units) below the measured number; the measured number lies above the stated range.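

In this assay, among the compounds shown here, the exchange of 2-methylcyclopropyl for oxan-2-yl on a carbonyl carbon gives a 34-fold higher number from compound 2 to compound 3 (1.53 log units; beyond the scatter), which is the first step that can be read, and it shows that this position is not indifferent to the group it carries. With the rest of the structure unchanged, this single exchange on the carbonyl carbon of the amide is enough to move the number well beyond the scatter. The entering oxan-2-yl differs from the leaving 2-methylcyclopropyl in ring size, in its ring oxygen and in its hydrogen-bond acceptor, all in one step, and nothing measured on these compounds separates those differences or accounts for the size of the step.

What the compounds shown leave open is which of those differences carries the step, and a cyclohexyl on the same carbonyl carbon would set the ring size apart from the ring oxygen. Also open, on these data alone, is how an open chain, such as tert-butyl or methoxyethyl, or a smaller ring such as cyclobutyl would read at this position.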